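Series notes: from compound 1 to compound 4

The source may hold more compounds than are shown below. What is called first, only, known or untested is meant among the compounds shown, and "the series" means these compounds.

For the measured compounds named here, compound 1 `O=C1C[C@H](O)C[C@@H](/C=C/c2c(Cl)cc(Cl)cc2-c2ccc(Cl)c(Cl)c2)O1` gives 25 nM in an assay for inhibition of 3-hydroxy-3-methylglutaryl-coenzyme A reductase (Rattus norvegicus) (a higher number here means a weaker inhibitor, a lower number a stronger inhibitor), the second highest of the three numbers measured so far. Compound 3 `Cc1cc(-c2cccc(Cl)c2/C=C/[C@@H]2C[C@@H](O)CC(=O)O2)ccc1F` gives 30 nM in this assay, within the scatter of compound 1, and compound 2 `Cc1ccc(C)c(-c2ccc(Cl)c(Cl)c2)c1/C=C/[C@@H]1C[C@@H](O)CC(=O)O1` gives 13 nM, also within the scatter of compound 1. Going by the values given here, no pair of measured compounds differs in only one place, so no step size is known. Compound 4 `Cc1ccc(-c2cc(Cl)cc(Cl)c2/C=C/[C@@H]2C[C@@H](O)CC(=O)O2)cc1` differs from compound 1 by 4-methylphenyl in place of 3,4-dichlorophenyl on an aromatic carbon, on an aromatic carbon ortho to a large group and meta to two chloro groups. Given the narrow range across all three measured compounds, the expected step of a 1.4-fold higher number from compound 1 to compound 4 (0.15 log units; within the scatter) is small, leaning toward a higher number, and need not exceed the scatter. Compound 4 is estimated at 35 nM, with a range from 12 nM to 100 nM.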

Compound 4, half-maximal inhibitory concentration: 190 nM
For compound 4 the middle estimate is 5.4-fold (0.73 log units) below the measured one, outside the stated range (above it).
By their numbers in this assay, from the lowest: compounds 2, 1 and 3 (each within the scatter of the next, the first and the last beyond it); then compound 4.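

For the compounds shown here, at this aromatic carbon, 4-methylphenyl in place of 3,4-dichlorophenyl gives a 7.6-fold higher number from compound 1 to compound 4 (0.88 log units; beyond the scatter) in this assay and is the first step that can be read. The earlier compounds shown here differ in more than one place, so they could not show that this position responds to such a change. No measurement in hand gives a reason for this step.

The change replaces both chloro groups at once, leaving the contribution of each unresolved. On these data alone, whether 4-chlorophenyl or 3-chlorophenyl at this position would hold the value of compound 1 remains open.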